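Ethyl to Methyl Ester on a Cytotoxic Chalcone Series

The source may report more compounds than this note shows. Statements on the series, on what has been measured and on what is new or still open speak of the compounds shown alone.

Measured so far:
Compound 1, `CCOC(=O)c1cc2cc(C=O)cc(C(C)CC)c2oc1=O`, gives 64300 nM.
Compound 2, `CCOC(=O)c1cc2cc(/C=C/C(=O)c3ccc(Cl)cc3)cc(C(C)CC)c2oc1=O`, gives 4540 nM.
Compound 3, `CCC(C)c1cc(C=O)cc2cc(C(=O)OC)c(=O)oc12`, gives 88000 nM.

All three numbers come from a functional assay on C-33-A cells (Homo sapiens) for cytotoxicity, read by sulforhodamine B assay, with a stated time of 48 h; on this read-out lower numbers stand for stronger inhibition and higher numbers for weaker inhibition. Compound 2 has the lowest number of the three; the difference between its core and the core of compound 1 is not broken down here. Compound 3 differs from compound 1 by hydrogen in place of methyl on a saturated chain carbon bound to an oxygen next to a carbonyl group, and in this assay that step is a 1.4-fold higher number from compound 1 to compound 3 (0.14 log units; within the scatter). The unmeasured compound 4, `CCC(C)c1cc(/C=C/C(=O)c2ccc(Cl)cc2)cc2cc(C(=O)OC)c(=O)oc12`, differs from compound 2 by hydrogen in place of methyl on a saturated chain carbon bound to an oxygen next to a carbonyl group, the same change at the same place. A step of similar size is expected, a 1.2-fold higher number from compound 2 to compound 4 (0.08 log units; within the scatter), because a 1.4-fold higher number from compound 1 to compound 3 (0.14 log units; within the scatter) stayed within the scatter. Compound 4 is therefore estimated at 5500 nM, with a range from 2500 nM to 13000 nM.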

Compound 4, half-maximal inhibitory concentration: 5900 nM
Beside the measured number, compound 4's estimate is 1.1-fold (0.03 log units) below it, and the stated range covers the measured number.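

In this assay, the change from ethoxycarbonyl to methoxycarbonyl on the core of compound 2 comes out as a 1.3-fold higher number from compound 2 to compound 4 (0.11 log units; within the scatter). Set beside the earlier step, the change reads the same on both cores: the same change on two cores in this assay, a 1.4-fold higher number (0.14 log units; within the scatter) from compound 1 to compound 3 and a 1.3-fold higher number (0.11 log units; within the scatter) from compound 2 to compound 4, 1.1-fold (0.02 log units) apart, within the scatter of two such steps. On these two cores, then, the ester can go from ethoxy to methoxy without moving the number beyond the scatter, but two pairs do not show that this would hold on any other core, and they say nothing about why.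

The compounds shown leave open whether a longer chain on the ester oxygen, a carboxylic acid or an amide in place of the ester would behave the same way. They also leave open how the change reads on any other cell line.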